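This account rests on a few compounds, and the source may have more. Where it says the series, first, only, none or still open, it means among the compounds named here.

In a functional assay on the whole organism for antagonist activity, with Mus musculus as the target, in the maximal electroshock model (on this read-out lower numbers stand for an effect already at smaller amounts and higher numbers for an effect only at larger amounts of compound), compound 1 `COC(=O)NC1=NC(c2ccccc2C)CN1` gives 55 mg/kg, compound 2 `COC(=O)NC1=NC(c2ccccc2F)CN1` gives 54 mg/kg and compound 3 `COC(=O)NC1=NC(c2ccccc2Cl)CN1` gives 50 mg/kg. Compound 1 therefore stands level with the other two measured compounds. The measured steps are a 1.0-fold lower number from compound 1 to compound 2 (0.01 log units; within the scatter), a 1.1-fold lower number from compound 1 to compound 3 (0.04 log units; within the scatter) and a 1.1-fold lower number from compound 2 to compound 3 (0.03 log units; within the scatter).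

Compound 4 `COC(=O)NC1=NC(c2cc(C)ccc2C)CN1` has not yet been measured. It keeps the core of compound 1 and differs by one change: methyl in place of hydrogen on an aromatic carbon, meta to a large group and para to a methyl group.

The measured steps bear on this change only indirectly. Each exchanges one of methyl, fluoro or chloro for another, and none of compounds 1, 2 or 3 carries a group on the aromatic carbon that changes in compound 4. The closest guide is a 1.1-fold lower number from compound 1 to compound 3 (0.04 log units; within the scatter), the larger of the two steps away from compound 1. No step beyond the scatter is therefore expected in this assay, in either direction, but without a direct precedent the range stays wide. The expected result is a 1.1-fold lower number from compound 1 to compound 4 (0.04 log units; within the scatter). For compound 4 the estimated value is 50 mg/kg, with an expected range from 25 mg/kg to 105 mg/kg.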

Compound 4, dose for half-maximal effect: about 100 mg/kg
Compound 4: the middle estimate sits 2.0-fold (0.30 log units) below what was measured; low and high end bracket the measured number.
By their numbers in this assay, from the lowest: compounds 3, 2, 1 and 4 (each within the scatter of the next).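

Methyl in place of hydrogen on the aromatic carbon meta to a large group and para to a methyl group gives a 1.8-fold higher number from compound 1 to compound 4 (0.26 log units; within the scatter) in this assay and is the first change in the series at this position, as compounds 1, 2 and 3 vary only the existing group on the aromatic ring. On this single pair, the position accepts a methyl group with the shared core unchanged, with no step beyond the scatter and an effect still recorded as a dose for half-maximal effect. No supporting measurement is available to explain the step or to separate any contribution of this methyl group from the scatter.

Open is whether this tolerance extends beyond methyl, since the compounds shown give no reading at this position for a larger or differently functionalised group such as methoxy, an amine or a carboxylic acid. Also open, on these data alone, is whether the same methyl group would give a similar step on the fluoro and chloro compounds 2 and 3, which carry hydrogen at this position.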